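This account rests on a few compounds, and the source may have more. Where it says the series, first, only, none or still open, it means among the compounds named here.

Three compounds of the shared core have numbers in a functional assay on MCF7 cells (Homo sapiens) for antiproliferative activity, read by MTT assay, with a stated time of 48 h; a lower number here means a stronger inhibitor, a higher number a weaker inhibitor. Compound 1 `O=C(/C=C/c1cccc(NC(=O)c2ccccc2Br)c1)c1nc2ccccc2[nH]1` gives 4520 nM, compound 2 `Cc1cc(C)cc(C(=O)Nc2cccc(/C=C/C(=O)c3nc4ccccc4[nH]3)c2)c1` gives 24600 nM, and compound 3 `Cc1ccccc1S(=O)(=O)Nc1cccc(/C=C/C(=O)c2nc3ccccc3[nH]2)c1` gives 4130 nM. Compound 3 has the smallest of the three numbers, though the gap a 1.1-fold lower number from compound 1 to compound 3 (0.04 log units; within the scatter) is within the scatter, while a 6.0-fold lower number from compound 2 to compound 3 (0.77 log units; beyond the scatter) is beyond it. Compound 4 `Cc1cccc(S(=O)(=O)Nc2cccc(/C=C/C(=O)c3nc4ccccc4[nH]3)c2)c1` differs from compound 3 by 3-methylphenyl in place of 2-methylphenyl on a sulfonyl sulfur. Among the compounds with values here, no measured step moves a substituent around the aryl on the sulfonyl; the only change of aryl substitution, a 5.4-fold higher number from compound 1 to compound 2 (0.74 log units; beyond the scatter), also swapped the group itself on a carbonyl and bears only loosely. The expected step is a 1.3-fold higher number from compound 3 to compound 4 (0.12 log units; within the scatter), within or just past the scatter. Compound 4 is therefore estimated at 5500 nM, with a range of 2000 nM to 15000 nM.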

Compound 4, half-maximal inhibitory concentration: 886 nM
Estimate against measurement, compound 4: 6.2-fold (0.79 log units) above, outside the stated range (below it).
By their numbers in this assay, from the lowest: compound 4; then compounds 3 and 1 (each within the scatter of the next); then compound 2.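

In this assay, 3-methylphenyl in place of 2-methylphenyl on a sulfonyl sulfur gives a 4.7-fold lower number from compound 3 to compound 4 (0.67 log units; beyond the scatter), so with the same atoms this place responds to where the methyl sits. The sulfonyl link alone does not set the number: compound 3 stays within the scatter of compound 1, yet the new sulfonamide shows a 5.1-fold lower number from compound 1 to compound 4 (0.71 log units; beyond the scatter) and a 28-fold lower number from compound 2 to compound 4 (1.44 log units; beyond the scatter). No measurement on hand accounts for the difference between the two methylphenyl groups.

From the compounds shown here alone, whether an ethyl or methoxy group in place of the methyl keeps this level remains open. So does whether 3-methylphenyl on a carbonyl carbon gives a similar result.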